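Bromo to Iodo on the Pyrimidine of Uracil Nucleotides

A few compounds are considered here, and "the series" means these few. Any claim that something is new, unique, unknown or untested is made for them only; others in the source may bear on it.

The measured compounds and their values:
compound 1 `O=c1[nH]c(=O)n([C@@H]2O[C@H](COP(=O)(O)O)[C@@H](O)[C@H]2O)cc1Br` gives 385 ug/mL;
compound 2 `O=c1[nH]c(=O)n([C@@H]2O[C@@H]3COP(=O)(O)O[C@H]3[C@H]2O)cc1I` gives 315 ug/mL;
compound 3 `O=c1[nH]c(=O)n([C@@H]2O[C@@H]3COP(=O)(O)O[C@H]3[C@H]2O)cc1Br` gives 315 ug/mL.

All three were tested in a functional assay on L1210 cells (Mus musculus); a lower number here means a stronger inhibitor, a higher number a weaker inhibitor. Compound 1 has the highest of the three numbers, but its gaps to compound 2 and to compound 3 are within the scatter, so no order among them can be claimed. The difference between the core of compound 1 and the core of compound 3 is not broken down here.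

One change is made twice: iodo in place of bromo on an aromatic carbon. From compound 3 to compound 2 this gave no change at the digits printed from compound 3 to compound 2 (within the scatter). Compound 4 `O=c1[nH]c(=O)n([C@@H]2O[C@H](COP(=O)(O)O)[C@@H](O)[C@H]2O)cc1I` is not yet measured; it arises from compound 1 by the same kind of change, (iodo in place of bromo on an aromatic carbon), at a place described in identical words.

Because no change at the digits printed from compound 3 to compound 2 (within the scatter) showed no change, the step for compound 4 is expected to be a 1.0-fold lower number from compound 1 to compound 4 (0.02 log units; within the scatter). Compound 4 is therefore estimated at 370 ug/mL, with a range from 200 ug/mL to 700 ug/mL.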

Compound 4, concentration for 50% inhibition: 703 ug/mL
Beside the measured number, compound 4's estimate is 1.9-fold (0.28 log units) below it; the measured number lies above the stated range.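

In this assay, iodo in place of bromo on the core of compound 1 gave a 1.8-fold higher number from compound 1 to compound 4 (0.26 log units; within the scatter). Set beside the same change on the core of compound 3, the two steps do not differ beyond the scatter: the same change on two cores in this assay, no change at the digits printed (within the scatter) from compound 3 to compound 2 and a 1.8-fold higher number (0.26 log units; within the scatter) from compound 1 to compound 4, 1.8-fold (0.26 log units) apart, within the scatter of two such steps. Within the data shown here, this shows that the change carries across these two cores without a demonstrable difference and that neither step is a clear effect, but it does not show that the cores respond identically, as only two pairs stand behind it and a smaller real difference would go unseen.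

As far as these compounds go, whether a chloro, a methyl or an amino group at that place would move the number beyond the scatter remains open. So does whether the change behaves alike on a third core.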